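Trimming the methoxy group from a weak cytotoxic anilide

The compounds below may be only part of what the source reports. "The series", "measured", "known", "first", "only" and "open" are said of these compounds alone.

Compound 1 `COc1cccc(O)c1C(=O)Nc1ccc(C#N)cc1` and compound 2 `COc1ccc(C(=O)Nc2ccc(C#N)cc2)c(O)c1` carry the same core with a hydroxy and a methoxy group placed differently. In a functional assay on HL-60 cells (Homo sapiens) for cytotoxicity, read by luminescence and CellTiter-Glo, with a stated time of 3 days (on this read-out higher numbers stand for weaker inhibition and lower numbers for stronger inhibition), compound 1 gives > 10000 nM, a limit of the assay rather than a number. In this assay, within the data shown here, compound 2 gives 5470 nM, the only real number so far. The other value is only (the limit of > 10000 nM in this assay, at which 1 of the 2 values shown sits). Compound 3 `N#Cc1ccc(NC(=O)c2ccccc2O)cc1` is not yet measured and differs from compound 2 by hydrogen in place of methoxy on an aromatic carbon. Among the measured compounds shown here, no measured step covers this change. The step from compound 2 to compound 3 is expected to be a 1.5-fold higher number from compound 2 to compound 3 (0.17 log units; within the scatter), toward weaker inhibition. Compound 3 is estimated at 8000 nM, between 3000 nM and 20000 nM.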

Compound 3, half-maximal inhibitory concentration: 4620 nM
The estimate for compound 3 lay 1.7-fold (0.24 log units) above the measured number; measured number inside the range.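

Removing the methoxy group from this position, meta to a hydroxy group and para to a large group, makes no difference that can be told from scatter in this assay: a 1.2-fold lower number from compound 2 to compound 3 (0.07 log units; within the scatter). Removing it from its other placement does count, with an at least 2.1-fold lower number from compound 1 to compound 3 (0.33 log units; beyond the scatter). That step starts from compound 1, whose value is a limit and not a number: the limit of > 10000 nM in this assay, at which 1 of the 3 values shown sits.

As far as these compounds go, whether an amine or a longer chain such as ethoxy at this position would shift the number remains open. So does the part played by the hydroxy group itself.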